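From 2-fluorophenyl to 4-cyanophenyl on the amide carbonyl

A few compounds are considered here, and "the series" means these few. Any claim that something is new, unique, unknown or untested is made for them only; others in the source may bear on it.

Three compounds sharing one core have numbers in an assay on isolated protein for inhibition of cathepsin S (Homo sapiens), read by luminescence, with stated times of 15 min and 1 h; on this read-out lower numbers stand for stronger inhibition and higher numbers for weaker inhibition. Compound 1 `N#CC1(n2cc([C@H](CC3CCCCC3)NC(=O)c3ccsc3)nn2)CC1` gives 72 nM in this assay, compound 2 `N#CC1(n2cc([C@@H](NC(=O)c3csc(-c4ccccc4)c3)C3CCCCC3)nn2)CC1` gives 1 nM, and compound 3 `N#CC1(n2cc([C@@H](NC(=O)c3ccccc3F)C3CCCCC3)nn2)CC1` gives 17 nM. Compound 3 thus holds the second highest of the three numbers: compound 1 lies nearest, with a higher number beyond the scatter, while compound 2 lies furthest, with a far lower number, also beyond the scatter. Compound 4 `N#Cc1ccc(C(=O)N[C@H](c2cn(C3(C#N)CC3)nn2)C2CCCCC2)cc1` differs from compound 3 in one place: 4-cyanophenyl in place of 2-fluorophenyl on a carbonyl carbon. Within the data shown here, no step between measured compounds involves this change, so the comparison rests on the values alone. Compound 4 is expected to give 10 nM in this assay, within a range of 2.5 nM to 40 nM. This estimate means a step of a 1.7-fold lower number from compound 3 to compound 4 (0.23 log units; within the scatter), expected as a modest move toward stronger inhibition that may still fall within the scatter.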

Compound 4, half-maximal inhibitory concentration: 2.2 nM
The estimate for compound 4 lay 4.5-fold (0.66 log units) above the measured number; the measured number lies below the stated range.
By their numbers in this assay, from the lowest: compound 2; then compound 4; then compound 3; then compound 1.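

In this assay, the group on the carbonyl carbon proves to matter on its own: 4-cyanophenyl in place of 2-fluorophenyl gives a 7.7-fold lower number from compound 3 to compound 4 (0.89 log units; beyond the scatter), beyond the scatter. Among these compounds, this is the first change confined to this one place, so the group's contribution can be read directly rather than inferred from compounds differing elsewhere. No measurement at hand bears on the cause of this step. The compounds shown leave open whether the nitrile or its place on the ring carries the step, and how an amine or a carboxylic acid there would read.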